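The source may report more compounds than this note shows. Statements on the series, on what has been measured and on what is new or still open speak of the compounds shown alone.

Compound 1 `O=C(/C=C/c1ccc([N+](=O)[O-])cc1)Nc1cc2c(Nc3ccc(F)c(Cl)c3)ncnc2cc1O[C@H]1CCOC1` and compound 2 `O=C(/C=C/c1ccccc1[N+](=O)[O-])Nc1cc2c(Nc3ccc(F)c(Cl)c3)ncnc2cc1O[C@H]1CCOC1` share a core and differ only in the nitrophenyl group on a double-bonded chain carbon. In a functional assay on PC-3 cells (Homo sapiens) for cytotoxicity, read by MTT assay, with a stated time of 72 h (a lower number here means a stronger inhibitor, a higher number a weaker inhibitor), compound 1 gives 22800 nM, while compound 2 gives 7760 nM, the lower of the two numbers and therefore the stronger result. Within the data shown here, the one measured step, a 2.9-fold lower number from compound 1 to compound 2 (0.47 log units; beyond the scatter), comes from 2-nitrophenyl in place of 4-nitrophenyl. It is modest, though beyond the scatter.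

Compound 3 `COc1cc(/C=C/C(=O)Nc2cc3c(Nc4ccc(F)c(Cl)c4)ncnc3cc2O[C@H]2CCOC2)cc(OC)c1O` carries a larger change at the same place: 4-hydroxy-3,5-dimethoxyphenyl in place of 2-nitrophenyl on a double-bonded chain carbon bound to a double-bonded chain carbon. In words, this is 4-hydroxy-3,5-dimethoxyphenyl in place of 2-nitrophenyl. The measured step of a 2.9-fold lower number from compound 1 to compound 2 (0.47 log units; beyond the scatter) bears on this only indirectly, showing that the number in this assay can move with a change at this place. Among the measured compounds shown here, no measured compound carries a hydroxy or methoxy group, so the data give no direction for the new step. The expected result is therefore no step beyond the scatter, and the estimate means a 1.0-fold higher number from compound 2 to compound 3 (0.01 log units; within the scatter). The estimate for compound 3 is 8000 nM, with an expected range from 2500 nM to 25000 nM.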

Compound 3, half-maximal inhibitory concentration: 26500 nM
For compound 3 the middle estimate is 3.3-fold (0.52 log units) below the measured one; measured number above the stated range.
By their numbers in this assay, from the lowest: compound 2; then compounds 1 and 3 (each within the scatter of the next).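

In this assay, a ring carrying no nitro group can now be compared at this place on a double-bonded chain carbon bound to a double-bonded chain carbon. Putting 4-hydroxy-3,5-dimethoxyphenyl in place of 2-nitrophenyl gives a 3.4-fold higher number from compound 2 to compound 3 (0.53 log units; beyond the scatter) and undoes the gain seen with 2-nitrophenyl, while the same group in place of 4-nitrophenyl gives a 1.2-fold higher number from compound 1 to compound 3 (0.07 log units; within the scatter) and leaves compound 3 and compound 1 indistinguishable, so among these three only compound 2 stands apart as the strongest. Nothing available here explains why 2-nitrophenyl differs from the other two groups.

Among these compounds, with only three groups at this place, it remains open whether the advantage of compound 2 depends on the nitro group itself or would also appear with a different group on the ring, and a simple unsubstituted phenyl would give a baseline for judging all three. From the compounds shown here alone, it is equally open how a 2-aminophenyl or a 2-carboxyphenyl group would compare, and whether the hydroxy group or the two methoxy groups of compound 3 matter on their own.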